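Nitro for methoxy on the sulfonate aryl ring

This account rests on a few compounds, and the source may have more. Where it says the series, first, only, none or still open, it means among the compounds named here.

compound 1 `N#C/C(=C\c1ccccc1OS(=O)(=O)c1ccc([N+](=O)[O-])cc1)C(=O)Nc1nnc(-c2cccs2)s1`: 40%
compound 2 `N#C/C(=C\c1ccccc1OS(=O)(=O)c1ccc([N+](=O)[O-])cc1)C(=O)Nc1nnc(Cc2cccc(F)c2)s1`: 65%
compound 3 `COc1ccc(S(=O)(=O)Oc2ccccc2/C=C(\C#N)C(=O)Nc2nnc(Cc3ccc(Cl)cc3)s2)cc1`: 77%

All three values come from a functional assay on RS4-11 cells (Homo sapiens) for inhibition, read by CCK-8 assay, with a stated time of 48 h, tested at 20 uM; on this read-out lower numbers stand for less inhibition of growth and higher numbers for more inhibition of growth at the one concentration tested. Compound 3 stands highest of the three, beyond the scatter above both compound 2 and compound 1.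

The next compound to be measured is compound 4 `N#C/C(=C\c1ccccc1OS(=O)(=O)c1ccc([N+](=O)[O-])cc1)C(=O)Nc1nnc(Cc2ccc(Cl)cc2)s1`. It differs from compound 3 in one place: nitro in place of methoxy on an aromatic carbon. This is nitro in place of methoxy on an aromatic carbon, para to a large group, so 4-methoxyphenyl becomes 4-nitrophenyl.

Among the measured compounds shown here, no measured step covers this change. For the measured compounds named here, the only measured step, a number 25 percentage points higher from compound 1 to compound 2 (beyond the scatter), is modest and is a different change, 3-fluorobenzyl in place of thiophen-2-yl, so it bears on the question only indirectly. Compound 4 carries the same nitro group as compound 2, and compound 2 gives 65%, which shows that a nitro compound in this series can reach a fairly high number. It differs from compound 3 in more than one place, however, so the two values do not isolate the change. A small downward step is therefore expected, possibly none beyond the scatter, and is estimated as a number 7 percentage points lower from compound 3 to compound 4 (within the scatter). The estimated value for compound 4 is 70%, with an expected range of 53% to 85%.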

Compound 4, percent growth inhibition at one concentration: 66%
The estimate for compound 4 lay 4 percentage points above the measured number; low and high end bracket the measured number.
By their numbers in this assay, from the lowest: compound 1; then compounds 2 and 4 (each within the scatter of the next); then compound 3.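

In this assay the sulfonate aryl ring now has a comparison that differs in one place: with the 4-chlorobenzyl group held fixed, 4-nitrophenyl in place of 4-methoxyphenyl gives a number 11 percentage points lower from compound 3 to compound 4 (beyond the scatter), so this position does respond to the change, though modestly. With the 4-nitrophenyl sulfonate held fixed, the other end of the molecule gives a number 1 percentage points higher from compound 2 to compound 4 (within the scatter) for 4-chlorophenyl in place of 3-fluorophenyl and a number 26 percentage points higher from compound 1 to compound 4 (beyond the scatter) for 4-chlorobenzyl in place of thiophen-2-yl, so the two halogenated benzyl groups cannot be told apart here, while both read beyond the scatter from thiophen-2-yl. Nothing at hand accounts for the difference between nitro and methoxy on this ring.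

From the compounds shown here alone, this reading rests on a single pair, and it remains open whether the same step appears with 3-fluorobenzyl or thiophen-2-yl on the other end of the molecule. Going by these compounds, it also remains open how an amine, a carboxylic acid or a plain hydrogen on the same ring carbon would compare with nitro and methoxy.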